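A Methyl on the Hydroxy Oxygen: Compound 1 to Compound 3

This account rests on a few compounds, and the source may have more. Where it says the series, first, only, none or still open, it means among the compounds named here.

Of the compounds shown here, two from this series have been measured in a functional assay on SW-620 cells (Homo sapiens) for inhibition, read by sulforhodamine B assay, with a stated time of 48 h, tested at 100 uM; on this read-out lower numbers stand for a stronger effect and higher numbers for a weaker effect at the one concentration tested. Compound 1 `O=C(Nc1cccc(-n2cc(-c3ccncc3)c(-c3cc(O)cc(Cl)c3)n2)c1)Nc1ccc(Cl)c(Cl)c1` carries a free hydroxy group on one of its aromatic rings, and in this assay compound 1 gives -36%. Compound 2 `COc1cc(Cl)cc(-c2nn(-c3cccc(NC(=O)Nc4cc(C(F)(F)F)cc(C(F)(F)F)c4)c3)cc2-c2ccncc2)c1` differs from compound 1 in more than one place, with a methoxy group in place of the hydroxy and a different pair of substituents on its outer ring, and in this assay compound 2 gives -72%. Of the two numbers, that of compound 1 is the higher, which on this read-out means the weaker effect, and the gap to compound 2 is wider than the usual scatter. Compound 2 changes two things at once, so its number alone cannot be credited to either change.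

Compound 3 `COc1cc(Cl)cc(-c2nn(-c3cccc(NC(=O)Nc4ccc(Cl)c(Cl)c4)c3)cc2-c2ccncc2)c1` keeps everything else of compound 1 and alters only the hydroxy group: methyl in place of hydrogen on an oxygen on an aromatic ring. Among the measured compounds shown here, no measured pair shows this single change on its own. A modest step toward a stronger effect is expected, a number 14 percentage points lower from compound 1 to compound 3 (beyond the scatter). The number for compound 3 is estimated at about -50%, within a range from -75% to -25%.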

Compound 3, a percentage reported as activity, at one concentration (the size of the read-out at that concentration, not a potency): 7%
Beside the measured number, compound 3's estimate is 57 percentage points below it; measured number outside the range, above it.
By their numbers in this assay, from the lowest: compound 2; then compound 1; then compound 3.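

In this assay, putting a methyl on this oxygen is far from a neutral edit: the result is a number 43 percentage points higher from compound 1 to compound 3 (beyond the scatter), so in the setting of compound 1 the effect at the one tested concentration depends strongly on whether this oxygen carries a hydrogen or a methyl. A methoxy group here does not by itself rule out a strong effect, since compound 3 gives 7% while compound 2, which carries the same methoxy group and differs only in the substituents on its outer ring, gives -72%. Nothing available explains why the step is so large.

From the compounds shown here alone, it remains open whether the loss follows from the missing hydrogen or from the added carbon, and an amine or an ethoxy group at this place would help to separate the two. Going by these compounds, it is also open whether the same change would weaken the effect in the setting of compound 2, where the hydroxy counterpart would supply the matching comparison.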